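Replacing 4-cyanophenyl: what to expect for compound 3

The source may hold more compounds than are shown below. What is called first, only, known or untested is meant among the compounds shown, and "the series" means these compounds.

Measured in a functional assay on OVCAR-8 cells (Homo sapiens); on this read-out higher numbers stand for weaker inhibition of growth and lower numbers for stronger inhibition of growth:
- compound 1 `N#Cc1ccc(/C=C/S(=O)(=O)Cc2ccc(Nc3ncnc4ccccc34)cc2)cc1`: > 100000 nM (a limit of the assay, not a number)
- compound 2 `O=S(=O)(/C=C/c1ccc(F)cc1Cl)Cc1ccc(Nc2ncnc3ccccc23)cc1`: 100000 nM

Compound 1 stands at the limit of > 100000 nM in this assay, at which 1 of the 2 values shown sits. Its true value is therefore unknown, and any comparison with it has an open end.

Compound 3 `O=S(=O)(/C=C/c1ccc(C(F)(F)F)cc1F)Cc1ccc(Nc2ncnc3ccccc23)cc1` keeps the shared core and changes a single group: 2-fluoro-4-(trifluoromethyl)phenyl in place of 4-cyanophenyl on a double-bonded chain carbon bound to a double-bonded chain carbon. Among the measured compounds shown here, the one measured step that bears on this change is a number no higher from compound 1 to compound 2 (the limit leaves the size open), with 2-chloro-4-fluorophenyl entering at the same place. That step has a direction but no readable size. For the measured compounds named here, it is also a single example, and its entering group differs from the one in compound 3.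

Going by the values given here, compound 2 at 100000 nM gives the only real number for such a replacement, so a value near it is the best guide. A small step towards stronger inhibition of growth in this assay is expected, or none that can be read. The expected size is an at least 1.4-fold lower number from compound 1 to compound 3 (0.15 log units; that floor lies within the scatter), and this is only an estimate. For compound 3 the estimated value is 70000 nM, with an expected range of 15000 nM to 100000 nM.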

Compound 3, concentration for 50% growth inhibition: 100000 nM
The estimate for compound 3 lay 1.4-fold (0.15 log units) below the measured number, and the stated range covers the measured number.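

In this assay, among the compounds shown here, putting 2-fluoro-4-(trifluoromethyl)phenyl in place of 2-chloro-4-fluorophenyl on the double-bonded chain carbon gives no change at the digits printed from compound 2 to compound 3 (within the scatter), which is the first comparison at this position that can be read as a size. Two entering rings with different groups attached thus give the same printed value, so the number for compound 2 is not a result peculiar to that one ring, although two compounds are a very small sample. Compound 1 gives > 100000 nM, which is a limit of the assay and not a number. Putting 2-fluoro-4-(trifluoromethyl)phenyl in place of 4-cyanophenyl gives a number no higher from compound 1 to compound 3 (the limit leaves the size open), and the steps that start from this limit cannot be read as a size: the limit of > 100000 nM in this assay, at which 1 of the 3 values shown sits.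

All three compounds shown carry a substituted phenyl ring at this place, so it remains open whether a ring bearing an amine or a carboxylic acid, or a plain unsubstituted phenyl, would give a clearly lower number. From the compounds shown here alone, it is also open whether the nitrile of compound 1 differs in any real way from the halogen-bearing rings, and whether any change here can bring stronger inhibition of growth.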